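A few compounds are considered here, and "the series" means these few. Any claim that something is new, unique, unknown or untested is made for them only; others in the source may bear on it.

Measured compounds:
- Compound 1 `NC(=O)c1ccc(-c2cccnc2)cc1O`: in an assay on cells for inhibition of MAP kinase-interacting serine/threonine-protein kinase 1 (Homo sapiens), read by mobility shift assay, with stated times of 10 min and 60 min, in the presence of a further agent that is not named here (a higher number here means a weaker inhibitor, a lower number a stronger inhibitor), compound 1 gives 4300 nM
- Compound 2 `CC(C)Oc1cc(-c2cncc(-c3cnn(C(C)C)c3)c2)ccc1C(N)=O`: compound 2 gives 85 nM
- Compound 3 `O=C(O)c1ccc(-c2cccnc2)s1`: compound 3 gives 10000 nM

Compound 2 has the lowest number of the three in this assay, and both compound 1 and compound 3 lie beyond the scatter above it. The unmeasured compound 4 `CC(C)Oc1cc(-c2cncc(-c3cnn(C4COC4)c3)c2)ccc1C(N)=O` differs from compound 2 in one place only: oxetan-3-yl in place of isopropyl on an aromatic nitrogen. Among the compounds with values here, no pair of measured compounds shares this difference, so there is no measured step to lean on. As the change sits far from the shared core and only one hetero atom enters, the step from compound 2 to compound 4 is expected to stay within the scatter, or at most a modest weakening, a 1.4-fold higher number from compound 2 to compound 4 (0.15 log units; within the scatter). Compound 4 is therefore estimated at 120 nM, with a range from 40 nM to 400 nM.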

Compound 4, half-maximal inhibitory concentration: 200 nM
Beside the measured number, compound 4's estimate is 1.7-fold (0.22 log units) below it; low and high end bracket the measured number.
By their numbers in this assay, from the lowest: compound 2; then compound 4; then compound 1; then compound 3.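

In this assay, the group on the aromatic nitrogen of the five-membered ring is not a silent spot: oxetan-3-yl in place of isopropyl gives a 2.4-fold higher number from compound 2 to compound 4 (0.37 log units; beyond the scatter), a modest step but beyond the scatter. Within the data shown here, the earlier compounds varied nothing here on its own, so this is the first reading for this position. Nothing measured here bears on why the number rises. The compounds shown leave open how a cyclopropyl group, an amine-bearing chain or a carboxylic acid on this nitrogen would read. From the compounds shown here alone, whether this change gives a similar step on another core also stays open.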